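A few compounds are considered here, and "the series" means these few. Any claim that something is new, unique, unknown or untested is made for them only; others in the source may bear on it.

Of the compounds shown here, three have been measured in a functional assay on the whole organism (Tail, strain ICR) with Mus musculus as the target, in the tail flick test, with a stated time of 120 min, at a dose of 25 umol/kg by the oral route; on this read-out higher numbers stand for a stronger effect at the one dose given and lower numbers for a weaker effect. Compound 1 `O=C(O)[C@@H]1CCCN1C(=O)CN(c1nc(Cl)nc2[nH]cnc12)C1CC1` gives 23.6%, compound 2 `C[C@H](NC(=O)CN(c1nc(Cl)nc2[nH]cnc12)C1CC1)C(=O)O` gives 28.4%, and compound 3 `C[C@H](NC(=O)CN(c1ncnc2c1ncn2C1CCCCO1)C1CC1)C(=O)OCc1ccccc1` gives 25.3%. Compound 2 holds the highest of the three numbers, yet compound 3 and compound 1 both sit within the scatter of it, so no order among the three can be claimed. Among the compounds with values here, the one step that can be read directly, a number 4.8 percentage points higher from compound 1 to compound 2 (within the scatter), is itself within the scatter.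

Compound 4 `O=C(O)C[C@H](NC(=O)CN(c1nc(Cl)nc2[nH]cnc12)C1CC1)C(=O)O` differs from compound 2 in one place: carboxy in place of hydrogen on a saturated chain carbon, two bonds along the chain from an amide-type nitrogen and a carbonyl carbon. Within the data shown here, no measured pair shows a carboxy entering in place of hydrogen, so the only bearing comes from the step between compound 1 and compound 2, where a change at the same part of the molecule moved the number very little. On that basis the step of a number 1.4 percentage points lower from compound 2 to compound 4 (within the scatter) is expected to stay within the scatter. Compound 4 is therefore estimated at 27%, with a range from 14% to 40%.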

Compound 4, a percentage reported as activity, at one dose (the size of the read-out at that dose, not a potency): 22%
Beside the measured number, compound 4's estimate is 5 percentage points above it, within the range that was stated.
By their numbers in this assay, from the lowest: compounds 4, 1, 3 and 2 (each within the scatter of the next).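

In this assay, within the data shown here, the change from methyl to carboxymethyl at this saturated chain carbon reads as a number 6.4 percentage points lower from compound 2 to compound 4 (within the scatter) and is the first direct reading of a group entering at this position. Even with 3 heavy atoms and a second carboxy group added there, compound 2 and compound 4 cannot be told apart on this read-out at the one dose given, so the position has shown no measurable sensitivity to this change. Nothing at hand explains the number of compound 4 or bears on what the added carboxy group does.

Still open, from the compounds shown here alone, is whether an amine, a hydroxyl or a longer chain ending in a carboxylic acid at this carbon would move the number beyond the scatter. Going by these compounds, whether compound 2 and compound 4 also stay together at other doses or times remains open as well.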